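This account rests on a few compounds, and the source may have more. Where it says the series, first, only, none or still open, it means among the compounds named here.

Compound 2 `Cc1nc(C(c2ccc(-c3ccc4cccc(F)c4c3)[nH]c2=O)C(C)C)[nH]c1C` is the reference point here. Among the compounds with values here, in an assay on CHO cells for displacement of a labelled ligand from prostaglandin E2 receptor EP3 subtype (Homo sapiens), read by radioligand binding (on this read-out lower numbers stand for stronger inhibition and higher numbers for weaker inhibition), compound 2 gives 7 nM, and its only measured neighbour, compound 1 `CC(C)C(Cc1ncc[nH]1)c1ccc(-c2ccc3cccc(F)c3c2)[nH]c1=O`, gives 11 nM in this assay, the two being separated by a 1.6-fold lower number from compound 1 to compound 2 (0.20 log units; within the scatter). Compound 3 `CC(C)C(c1nnc[nH]1)c1ccc(-c2ccc3cccc(F)c3c2)[nH]c1=O` is not yet measured. It differs from compound 2 in one place: 4H-1,2,4-triazol-3-yl in place of 4,5-dimethyl-1H-imidazol-2-yl on a saturated chain carbon bound to an aromatic carbon and a saturated chain carbon. Within the data shown here, the only step that bears on this change is the one from compound 1 to compound 2, which also altered the group on that same saturated chain carbon and produced a 1.6-fold lower number from compound 1 to compound 2 (0.20 log units; within the scatter), a shift that does not rise above the scatter. On that basis no step beyond the scatter is expected for compound 3 in this assay, and the estimated step is a 1.4-fold higher number from compound 2 to compound 3 (0.15 log units; within the scatter). Compound 3 is therefore expected to give about 10 nM in this assay, estimated to lie between 4 nM and 30 nM.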

Compound 3, inhibition constant: 12 nM
Compound 3: middle estimate off by 1.2-fold (0.08 log units), on the low side; the measured number falls inside the stated range.
By their numbers in this assay, from the lowest: compounds 2, 1 and 3 (each within the scatter of the next).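

At this position on the saturated chain carbon, this assay shows a 1.7-fold higher number from compound 2 to compound 3 (0.23 log units; within the scatter) when 4H-1,2,4-triazol-3-yl replaces 4,5-dimethyl-1H-imidazol-2-yl, and a 1.1-fold higher number from compound 1 to compound 3 (0.04 log units; within the scatter) when it replaces (1H-imidazol-2-yl)methyl in the second comparison. The position therefore now holds three different groups whose printed steps all stay within the scatter, and this range includes a five-membered aromatic ring with 3 hetero atoms and no methyl groups. Nothing available offers a reason why these changes leave the read-out so little altered.

Going by these compounds, whether a carboxylic acid or a plain amine on that saturated chain carbon would also stay within the scatter remains open. So does whether any five-membered aromatic ring is required there, which a longer alkyl chain in its place could test.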